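Compound 4: carboxy in place of tert-butyl

The source may hold more compounds than are shown below. What is called first, only, known or untested is meant among the compounds shown, and "the series" means these compounds.

The series is compared in an assay on microsomes for inhibition of acyl-CoA:cholesterol acyltransferase (Oryctolagus cuniculus); a higher number here means a weaker inhibitor, a lower number a stronger inhibitor. Compound 1 `Cc1ccccc1C1(CNC(=O)Nc2c(C(C)C)cccc2C(C)C)CCCC1` gives 17 nM; compound 3 `CC(C)c1cccc(C(C)C)c1NC(=O)NCC1(c2ccc(F)cc2)CCCC1` gives 23 nM; compound 2 `CC(C)c1cccc(C(C)C)c1NC(=O)NCC1(c2ccc(C(C)(C)C)cc2)CCCC1` gives 63 nM. Compound 2 stands highest of the three numbers, with compound 3 nearest and compound 1 furthest. The step of a 3.7-fold higher number from compound 1 to compound 2 (0.57 log units; beyond the scatter) and the step of a 2.7-fold lower number from compound 2 to compound 3 (0.44 log units; beyond the scatter) are both beyond the scatter, while a 1.4-fold higher number from compound 1 to compound 3 (0.13 log units; within the scatter) lies within it.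

Compound 4 `CC(C)c1cccc(C(C)C)c1NC(=O)NCC1(c2ccc(C(=O)O)cc2)CCCC1` differs from compound 2 by carboxy in place of tert-butyl on an aromatic carbon. The step of a 2.7-fold lower number from compound 2 to compound 3 (0.44 log units; beyond the scatter) is the one that bears on this change most directly: there the tert-butyl was also removed from the same aromatic carbon, and the number fell. Among the compounds with values here, no measured compound carries a carboxy, so what that group itself does is not known from these data. The expectation is a modest lower number in this assay, in the direction seen for compound 3, and compound 4 is estimated at 30 nM, with a plausible range from 10 nM to 120 nM, which means an expected step of a 2.1-fold lower number from compound 2 to compound 4 (0.32 log units; beyond the scatter).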

Compound 4, half-maximal inhibitory concentration: 3100 nM
The estimate for compound 4 lay 100-fold (2.01 log units) below the measured number; measured number above the stated range.
By their numbers in this assay, from the lowest: compounds 1 and 3 (each within the scatter of the next); then compound 2; then compound 4.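

In this assay, this aromatic carbon proves far from indifferent to what it carries: swapping tert-butyl for fluoro had moved the number only by a 2.7-fold lower number from compound 2 to compound 3 (0.44 log units; beyond the scatter), whereas carboxy gives a 49-fold higher number from compound 2 to compound 4 (1.69 log units; beyond the scatter), and the same change measured from the fluoro compound gives a 130-fold higher number from compound 3 to compound 4 (2.13 log units; beyond the scatter). Losing the tert-butyl is therefore not enough to lower the number, since the direction seen with fluoro reverses with carboxy, and the gap is just as plain against the core of compound 1, with a 180-fold higher number from compound 1 to compound 4 (2.26 log units; beyond the scatter), so all three earlier aryl groups stand well clear of 4-carboxyphenyl. The carboxy brings a hydrogen-bond donor and a hydrogen-bond acceptor that tert-butyl lacks, but no measurement here links the higher number to either of them or to any other feature of the group.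

The compounds shown leave open whether a methyl ester, a primary amide or a hydroxymethyl on this carbon would stay near compound 2 or follow compound 4. On these data alone, it also remains open whether an amine here would raise the number as sharply as the carboxy does.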